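The compounds below may be only part of what the source reports. "The series", "measured", "known", "first", "only" and "open" are said of these compounds alone.

Three related compounds have so far been tested in an in vitro assay on BTI-TN-5B1-4 cells for inhibition of Amine oxidase [flavin-containing] B (Homo sapiens); a lower number here means a stronger inhibitor, a higher number a weaker inhibitor. Compound 1 `Cc1ccc([C@@H]2CC(=O)c3ccc(C)cc3O2)cc1` carries two methyl groups, and in this assay compound 1 gives 590 nM. Compound 2 `Cc1ccc2c(c1)O[C@H](c1ccccc1)CC2=O` keeps one of those methyl groups, and compound 2 gives 110 nM. Compound 3 `Cc1ccc(C2CC(=O)c3ccccc3O2)cc1` keeps the other methyl group instead, and compound 3 gives 2070 nM, the highest of the three numbers.

One single change has already been measured here: compound 2 differs from compound 1 by hydrogen in place of methyl on an aromatic carbon, and this change made a 5.4-fold lower number from compound 1 to compound 2 (0.73 log units; beyond the scatter).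

Compound 4 `O=C1CC(c2ccccc2)Oc2ccccc21` has not yet been measured. It arises from compound 3 by hydrogen in place of methyl on an aromatic carbon. For the measured compounds named here, this is the same change as the one from compound 1 to compound 2, made in the same place as described there. The cores on which the two changes are made are not identical, however, and the difference between the two cores is not broken down here, so the earlier step need not carry over exactly.

Because the measured step was a 5.4-fold lower number from compound 1 to compound 2 (0.73 log units; beyond the scatter), a step of broadly similar size is expected from compound 3 to its counterpart, namely a 4.6-fold lower number from compound 3 to compound 4 (0.66 log units; beyond the scatter). Compound 4 is therefore estimated to give 450 nM in this assay, with a likely range from 150 nM to 1400 nM.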

Compound 4, half-maximal inhibitory concentration: 2870 nM
Beside the measured number, compound 4's estimate is 6.4-fold (0.80 log units) below it; measured number outside the range, above it.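

In this assay, hydrogen in place of methyl on an aromatic carbon gives a 1.4-fold higher number from compound 3 to compound 4 (0.14 log units; within the scatter), so compound 3 and compound 4 cannot be told apart on this measurement. The same change on the core of compound 1 moved the number well beyond the scatter, so the size of the first step does not carry over to the second core, and the effect of this change here depends on the core that carries it: the same change on two cores in this assay, a 5.4-fold lower number (0.73 log units; beyond the scatter) from compound 1 to compound 2 and a 1.4-fold higher number (0.14 log units; within the scatter) from compound 3 to compound 4, 7.4-fold (0.87 log units) apart, beyond the scatter of two such steps. For the compounds shown here, this shows only that the step failed to transfer between these two pairs of compounds; it does not show which difference between the cores is responsible, and two pairs give no rule for how the change would behave on any further core.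

The compounds shown carry only hydrogen or methyl at the ring positions that vary, so it remains open how a chlorine atom, a methoxy group or an amine would behave at the same place. As far as these compounds go, it also remains open whether such a group would give similar steps on both cores or would differ between them as the methyl group does.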